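Changing the Amide Aryl Group: Compounds 2 and 3

The compounds below may be only part of what the source reports. "The series", "measured", "known", "first", "only" and "open" are said of these compounds alone.

Compound 1 `O=C(Nc1ccccc1)c1csc(Cc2c(Cl)cccc2Cl)n1`: > 4000 nM
Compound 2 `COc1ccc(NC(=O)c2csc(Cc3c(Cl)cccc3Cl)n2)cn1`: > 4000 nM

In an assay on CHO cells, read by calcium flux (a lower number here means a stronger inhibitor, a higher number a weaker inhibitor), compound 1 gives > 4000 nM, which is a limit of the assay rather than a number. In this assay compound 2 gives > 4000 nM, also a limit. Going by the values given here, the one measured step, a step that the two limits leave unreadable from compound 1 to compound 2, therefore cannot be read, since both values sit at the limit (the limit of > 4000 nM in this assay, at which 2 of the 2 values shown sit). Compound 2 thus stands at the limit of this assay, with no number of its own.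

Compound 3 `O=C(Nc1ccc(Br)cn1)c1csc(Cc2c(Cl)cccc2Cl)n1` has not yet been tested. It differs from compound 2 by 5-bromopyridin-2-yl in place of 6-methoxypyridin-3-yl on an amide-type nitrogen. Among the compounds with values here, no measured step bears on this change, as the only step in the set is unreadable. For compound 3 the step expected in this assay is a step that the limit leaves unreadable from compound 2 to compound 3, none beyond the scatter. Compound 3 is expected to give about 8000 nM, within 2000 nM to 40000 nM, and most likely only a limit again.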

Compound 3, half-maximal inhibitory concentration: > 4000 nM
Compound 3: a limit, no number (the forecaster's own chance of this, stated with the estimate: 80%); the middle value is on the limit's open side.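

Compound 3 joins compound 1 and compound 2 at a limit of this assay rather than a number, so no step among the three can be read: the limit of > 4000 nM in this assay, at which 3 of the 3 values shown sit.

The compounds shown leave open whether any amide aryl group on the shared core gives a measurable value, and how these three groups compare.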